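Lengthening the chain: from compound 3 to compound 4

The compounds below may be only part of what the source reports. "The series", "measured", "known", "first", "only" and "open" are said of these compounds alone.

Measured in an assay on membranes from liver for displacement of a labelled ligand from Sigma intracellular receptor 2 (Rattus norvegicus), read by scintillation counting, with a stated time of 120 min, in the presence of a further agent that is not named here; a higher number here means a weaker inhibitor, a lower number a stronger inhibitor: compound 1 `c1ccc(CCCCNC2CCc3ccsc3CC2)cc1` gives 5.7 nM; compound 2 `OCc1cc2c(s1)CCC(NCCCCc1ccccc1)CC2` gives 73 nM; compound 3 `Brc1cc2c(s1)CCC(NCCCc1ccccc1)CC2` gives 43 nM.

Compound 3 gives the second highest of the three numbers: it sits within the scatter of compound 2 and well above compound 1. Compound 4 `Brc1cc2c(s1)CCC(NCCCCc1ccccc1)CC2` differs from compound 3 in one place: benzyl in place of phenyl on a saturated chain carbon, three bonds along the chain from an amine nitrogen. Among the compounds with values here, the only step measured so far, a 13-fold higher number from compound 1 to compound 2 (1.11 log units; beyond the scatter), alters a group on the aromatic ring, not the chain, so no measured step bears on this change. Compounds 1 and 2, which share the longer chain of compound 4, span a wide range of values. For compound 4 the estimate is therefore close to compound 3, with a wide range, a 1.7-fold lower number from compound 3 to compound 4 (0.24 log units; within the scatter), giving an expected 25 nM between 7 nM and 90 nM.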

Compound 4, inhibition constant: 13 nM
Compound 4: the middle estimate sits 1.9-fold (0.28 log units) above what was measured; the measured number falls inside the stated range.
By their numbers in this assay, from the lowest: compound 1; then compound 4; then compounds 3 and 2 (each within the scatter of the next).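

Within this series, chain length alone moves the number in this assay: with bromo kept on the ring, the benzyl change gives (a 3.3-fold lower number from compound 3 to compound 4 (0.52 log units; beyond the scatter)). With the longer chain kept, the ring group also counts, as bromo in place of hydroxymethyl gives (a 5.6-fold lower number from compound 2 to compound 4 (0.75 log units; beyond the scatter)), while bromo in place of hydrogen gives (a 2.3-fold higher number from compound 1 to compound 4 (0.36 log units; beyond the scatter)), so neither substituted compound matches the unsubstituted one. Nothing measured here explains why these changes shift the number.

From the compounds shown here alone, whether a still longer chain would lower the number further remains open. So does whether an amine or a carboxylic acid on that ring carbon would match hydrogen.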